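Fluoro to Trifluoromethylphenyl Ether at the Chain Terminus

The compounds below may be only part of what the source reports. "The series", "measured", "known", "first", "only" and "open" are said of these compounds alone.

Compound 2 `CC(C)[C@H](NC(=O)COc1cccc2ccccc12)C(=O)N[C@@H](CC(=O)O)C(=O)COc1ccc(F)cc1` and compound 3 `CC(C)[C@H](NC(=O)COc1cccc2ccccc12)C(=O)N[C@@H](CC(=O)O)C(=O)COc1cccc(C(F)(F)F)c1F` share one core and differ only in the aryl ether on the oxygen on a saturated carbon. In a functional assay on Jurkat cells (Homo sapiens) (on this read-out higher numbers stand for weaker inhibition and lower numbers for stronger inhibition), compound 2 reaches only the limit > 100000 nM, so no number is known for it. Compound 2 sits at the limit of > 100000 nM in this assay, at which 1 of the 2 values shown sits. Compound 1 `CC(C)[C@H](NC(=O)COc1cccc2ccccc12)C(=O)N[C@@H](CC(=O)O)C(=O)COc1ccc(Oc2ccc(C(F)(F)F)cc2)cc1` carries a 4-(trifluoromethyl)phenoxy group where compound 2 carries fluoro, and in this assay compound 1 gives 9300 nM. The step of an at least 10-fold higher number from compound 1 to compound 2 (1.03 log units; beyond the scatter) is the only measured one that bears on the present change, and it shows how much inhibition is lost when that group is taken away. Compound 3 arises by the change (2-fluoro-3-(trifluoromethyl)phenyl in place of 4-fluorophenyl on an oxygen on a saturated carbon). This brings a trifluoromethyl back onto the aryl ether, though onto the same ring rather than onto a second phenoxy. Compound 3 is therefore expected to gain an at least 3.3-fold lower number from compound 2 to compound 3 (0.52 log units; beyond the scatter). It is not expected to recover fully what compound 1 shows at 9300 nM. The estimated value for compound 3 in this assay is 30000 nM, within a range from 8000 nM to 100000 nM.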

Compound 3, half-maximal inhibitory concentration: 50400 nM
Compound 3: the middle estimate sits 1.7-fold (0.23 log units) below what was measured; measured number inside the range.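

With compound 3, the aryl group on the oxygen on a saturated carbon gives a measured number while keeping a single aromatic ring: in this assay compound 3 gives 50400 nM. A second phenoxy is therefore not required for a reading at this position, although compound 1, at 9300 nM, still shows the lower number of the two. The gain over the 4-fluorophenyl group remains unproven, since the step reads an at least 1.9-fold lower number from compound 2 to compound 3 (0.29 log units; that floor lies within the scatter) and only its floor is known, while compound 2 has a limit of the assay rather than a number: the limit of > 100000 nM in this assay, at which 1 of the 3 values shown sits.

The compounds shown do not separate the share of the fluoro from that of the trifluoromethyl in 2-fluoro-3-(trifluoromethyl)phenyl, as no phenyl carrying only one of the two appears among them. They also leave open whether the lower number of compound 1 comes from its second aromatic ring or from the trifluoromethyl on it, which a plain phenoxy would address, and how a nitrile or a methoxy group on the aryl ether would read in this assay.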